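The compounds below may be only part of what the source reports. "The series", "measured", "known", "first", "only" and "open" are said of these compounds alone.

Two compounds of the series carry numbers in a functional assay on HUVEC cells (Homo sapiens) for inhibition, read by ELISA; a lower number here means a stronger inhibitor, a higher number a weaker inhibitor. Compound 1 `CCc1nnc([S+]([O-])Cc2ncc(C)c(OC)c2C)o1` gives 12000 nM in this assay. Compound 2 `[O-][S+](Cc1ccccc1)c1nnc(-c2ccccn2)o1` gives 5000 nM in this assay. Compound 1 thus holds the highest of the two numbers; its nearest neighbour is compound 2, whose number is lower by a gap beyond the usual scatter. Among the measured compounds shown here, no pair of measured compounds differs in only one place, so the weight of any single change on the shared core has not yet been measured.

Compound 3 `COc1c(C)cnc(C[S+]([O-])c2nnc(C)o2)c1C` differs from compound 1 in one place: hydrogen in place of methyl on a saturated chain carbon bound to an aromatic carbon. Compound 2 differs from compound 1 in more than one place, so its value shows only that another substitution pattern on the shared core reaches a lower number; it carries no information on this particular change.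

For compound 3 the step of a 1.3-fold higher number from compound 1 to compound 3 (0.10 log units; within the scatter) is expected to be small, at most a slight move toward a higher number, and may well fall within the scatter. Compound 3 is estimated at 15000 nM in this assay, within a range from 6000 nM to 40000 nM.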

Compound 3, half-maximal inhibitory concentration: 10000 nM
The estimate for compound 3 lay 1.5-fold (0.18 log units) above the measured number; measured number inside the range.
By their numbers in this assay, from the lowest: compounds 2, 3 and 1 (each within the scatter of the next, the first and the last beyond it).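

The series now has its first step across a single place in this assay: hydrogen in place of methyl on a saturated chain carbon bound to an aromatic carbon, which is the same difference as ethyl to methyl, gives a 1.2-fold lower number from compound 1 to compound 3 (0.08 log units; within the scatter), so the number does not respond measurably to this change. Ethyl and methyl at this place therefore cannot be told apart in this assay, and this pair gives no sign that the length of the chain, over these two members, matters for the number on the core of compound 1. No measurement at hand explains this result or says what the group at this place does.

On these data alone, it remains open whether the flat result holds beyond these two groups, for example with a longer chain such as propyl or butyl, or with a group of another kind such as an amine or a carboxylic acid at the same place. As far as these compounds go, compound 2 differs from compound 1 and compound 3 in more than one place, so which of its differences goes with its lower number than compound 1 also remains open.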